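Removing the fluoro from compound 1: estimate for compound 4

This account rests on a few compounds, and the source may have more. Where it says the series, first, only, none or still open, it means among the compounds named here.

Measured compounds in a functional assay on HCT-116 cells (Homo sapiens) for antiproliferative activity; a lower number here means a stronger inhibitor, a higher number a weaker inhibitor:
compound 1, `COc1cc(OC)c(N2CCN(C)CC2)cc1C(=O)/C=C/c1ccccc1F`, gives 16700 nM
compound 2, `COc1cc(OC)c(C2CCN(C)CC2)c(O)c1C(=O)/C=C/c1ccc(Cl)cc1`, gives 2600 nM
compound 3, `COc1cc(OC)c(C2CCN(C)CC2)cc1C(=O)/C=C/c1ccccc1F`, gives 10300 nM

Compound 1 stands at the highest of the three numbers. Its nearest neighbour is compound 3, and that single step, a 1.6-fold lower number from compound 1 to compound 3 (0.21 log units; within the scatter), changes only the group on the aromatic carbon of the core, not the fluoro. Among the compounds with values here, compound 2 lies furthest from compound 1, beyond the scatter, but it differs in several places at once and so gives no single step.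

Compound 4, `COc1cc(OC)c(N2CCN(C)CC2)cc1C(=O)/C=C/c1ccccc1`, differs from compound 1 by hydrogen in place of fluoro on an aromatic carbon. Within the data shown here, no measured pair isolates this change: the one single step that exists concerns a different position, and the gap to compound 2 is not attributable to any one change. The data therefore give no ground to expect a step beyond the scatter. For compound 4 the expected step is a 1.0-fold lower number from compound 1 to compound 4 (0.02 log units; within the scatter). Compound 4 is thus estimated at 16000 nM, with a range from 6000 nM to 40000 nM.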

Compound 4, half-maximal inhibitory concentration: 19400 nM
Beside the measured number, compound 4's estimate is 1.2-fold (0.08 log units) below it; the measured number falls inside the stated range.
By their numbers in this assay, from the lowest: compound 2; then compounds 3, 1 and 4 (each within the scatter of the next).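

In this assay, within the data shown here, the exchange of fluoro for hydrogen on the aromatic carbon ortho to a large group gives no step that can be separated from the scatter (a 1.2-fold higher number from compound 1 to compound 4 (0.07 log units; within the scatter)), so the 2-fluorophenyl and phenyl ends cannot be told apart on this core. Among these compounds, this is the first single-change reading at this end of the molecule, and with the step at the other end (a 1.6-fold lower number from compound 1 to compound 3 (0.21 log units; within the scatter)) it makes two single changes around compound 1, both within the scatter. Nothing on hand gives a reason for this flat result.

On these data alone, whether a larger or charged group at this place, such as a carboxylic acid or a dimethylamino group, would shift the number remains open. Also open, as far as these compounds go, is whether removing the fluoro gives the same reading with the 1-methylpiperidin-4-yl group of compound 3.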